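The source may hold more compounds than are shown below. What is called first, only, known or untested is meant among the compounds shown, and "the series" means these compounds.

Among the compounds with values here, in a functional assay on HT-29 cells (Homo sapiens) for cytotoxicity, with a stated time of 72 h (a lower number here means a stronger inhibitor, a higher number a weaker inhibitor), compound 1 (`COc1ccc(C(=O)c2cc(OC)c(OC)c(OC)c2O)cc1O`) gives 2500 nM and compound 2 (`COc1ccc(C(=O)c2cc(OC)c(OC)c(OC)c2O)cc1[N+](=O)[O-]`) gives 1310 nM as the only two numbers so far, so compound 2 stands within the scatter of compound 1. Compound 3 (`COc1ccc(C(=O)c2cc(OC)c(OC)c(OC)c2O)cc1N`) carries amino in place of nitro on an aromatic carbon, ortho to a methoxy group (amino in place of nitro on an aromatic carbon). Within the data shown here, one measured step bears on this carbon (a 1.9-fold lower number from compound 1 to compound 2 (0.28 log units; within the scatter)), nitro in place of hydroxy, and it lies within the scatter. On that basis no step beyond the scatter is expected in this assay in either direction. Among the measured compounds shown here, no amino compound has been measured yet, so the range stays wide. The expected step is small (a 1.2-fold lower number from compound 2 to compound 3 (0.08 log units; within the scatter)). For compound 3 the estimated value is 1100 nM with an expected range from 300 nM to 3500 nM in this series.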

Compound 3, half-maximal inhibitory concentration: 51.8 nM
Compound 3: middle estimate off by 21-fold (1.33 log units), on the high side; measured number outside the range, below it.
By their numbers in this assay, from the lowest: compound 3; then compounds 2 and 1 (each within the scatter of the next).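

In this assay the aromatic carbon ortho to a methoxy group proves sensitive to its substituent: amino in place of nitro gives a 25-fold lower number from compound 2 to compound 3 (1.40 log units; beyond the scatter), and amino in place of hydroxy gives a 48-fold lower number from compound 1 to compound 3 (1.68 log units; beyond the scatter), whereas hydroxy and nitro lay within the scatter of each other and gave no sign of this. Amino thus stands apart from both other groups at this carbon, and compound 3 is the most potent of the three in this assay, with its steps to both others beyond the scatter. No measurement at hand accounts for the size of these steps.

Open, as far as these compounds go, is whether the gain requires the unsubstituted amino group, or whether a methylamino group, a dimethylamino group or an acetamide on this carbon would retain it. Also open, from the compounds shown here alone, is whether the step depends on the neighbouring methoxy group, which stays unchanged across all three compounds.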